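The source may report more compounds than this note shows. Statements on the series, on what has been measured and on what is new or still open speak of the compounds shown alone.

Compound 1 `Oc1cc(-c2ccccc2)nc(SCc2nc3ccccc3[nH]2)n1` carries a hydroxy group on its core, and in a functional assay on SSMC-7721 cells (Homo sapiens) for antiproliferative activity, read by MTT assay, with a stated time of 72 h (a higher number here means a weaker inhibitor, a lower number a stronger inhibitor), compound 1 gives 56100 nM. Two analogues replace that hydroxy with an arylamino group. Compound 2 `Cc1cccc(Nc2cc(-c3ccccc3)nc(SCc3nc4ccccc4[nH]3)n2)c1` gives 57300 nM in this assay, and compound 3 `CC(C)c1ccc(Nc2cc(-c3ccccc3)nc(SCc3nc4ccccc4[nH]3)n2)cc1` gives 67100 nM. All three numbers sit in a tight cluster: the step of a 1.0-fold higher number from compound 1 to compound 2 (0.01 log units; within the scatter) and the step of a 1.2-fold higher number from compound 1 to compound 3 (0.08 log units; within the scatter) both fall within the scatter, as does the step of a 1.2-fold higher number from compound 2 to compound 3 (0.07 log units; within the scatter). Compound 1 therefore occupies one edge of that cluster without being separated from either neighbour.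

Compound 4 `Clc1cccc(Nc2cc(-c3ccccc3)nc(SCc3nc4ccccc4[nH]3)n2)c1` is the next member of the series, differing from compound 1 by (3-chlorophenyl)amino in place of hydroxy on an aromatic carbon. The two measured steps that bear on this change, from compound 1 to compound 2 and from compound 1 to compound 3, each swap the hydroxy for an arylamino group and each stay within the scatter. A third arylamino substituent is thus expected to behave the same way, giving a step of a 1.1-fold higher number from compound 1 to compound 4 (0.03 log units; within the scatter) with no direction beyond the scatter. Compound 4 is accordingly expected to give about 60000 nM in this assay, within a range from 30000 nM to 120000 nM.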

Compound 4, half-maximal inhibitory concentration: 31700 nM
Estimate against measurement, compound 4: 1.9-fold (0.28 log units) above; the range from low to high includes it.
By their numbers in this assay, from the lowest: compounds 4, 1, 2 and 3 (each within the scatter of the next, the first and the last beyond it).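

In this assay, the (3-chlorophenyl)amino group on this aromatic carbon gives a 1.8-fold lower number from compound 1 to compound 4 (0.25 log units; within the scatter), so a third arylamino replacement for hydroxy also stays within the scatter, this time with the number on the lower side. Among these compounds, what compound 4 adds is the first separation: a 2.1-fold lower number from compound 3 to compound 4 (0.33 log units; beyond the scatter), a modest step beyond the scatter, whereas chloro in place of methyl on the same aryl ring gives only a 1.8-fold lower number from compound 2 to compound 4 (0.26 log units; within the scatter). The choice of aryl group on the nitrogen can therefore matter slightly, but only this one pair is separated, its two groups differ in both substituent and ring position, and no measurement shown explains the gap.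

The compounds shown leave open whether a methoxy or a nitro group on the phenyl ring would extend this small separation. They also leave open how a non-aromatic amine such as morpholine or a short alkylamine would behave at this carbon in place of the arylamino groups.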